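Thiophen-2-yl gives way to thiophen-3-yl

The source may hold more compounds than are shown below. What is called first, only, known or untested is meant among the compounds shown, and "the series" means these compounds.

Measured in a functional assay on HepG2 cells (Homo sapiens) for antiproliferative activity, read by XTT assay, with a stated time of 72 h; on this read-out lower numbers stand for stronger inhibition and higher numbers for weaker inhibition:
- compound 1 `CN(C)c1ncnc2c1c(-c1ccsc1)cn2[C@@H]1O[C@H](CO)[C@@H](O)[C@H]1O`: > 20000 nM
- compound 2 `Cc1ncnc2c1c(-c1cccs1)cn2[C@@H]1O[C@H](CO)[C@@H](O)[C@H]1O`: > 15000 nM

Neither entry is a number. Compound 2 stands at the limit of > 15000 nM in this assay, at which 1 of the 2 values shown sits. Compound 1 stands at the limit of > 20000 nM in this assay, at which 1 of the 2 values shown sits. With only these limits in hand, the two compounds cannot be ranked against each other in this assay.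

Compound 3 `Cc1ncnc2c1c(-c1ccsc1)cn2[C@@H]1O[C@H](CO)[C@@H](O)[C@H]1O` has the same atoms as compound 2, joined differently. It carries thiophen-3-yl in place of thiophen-2-yl on an aromatic carbon of a five-membered aromatic ring with 1 nitrogen (thiophen-3-yl in place of thiophen-2-yl on an aromatic carbon). Within the data shown here, no measured pair shows what this exchange does. The starting point for compound 2 is only its limit of > 15000 nM. The expectation is therefore no step beyond the scatter in this assay, in either direction, and the assay may well report only a limit again. The estimated change is a number no higher from compound 2 to compound 3 (the limit leaves the size open). Compound 3 is expected to come in at about 15000 nM, with an estimated range of 4000 nM to 30000 nM.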

Compound 3, half-maximal inhibitory concentration: 4720 nM
Compound 3: middle estimate off by 3.2-fold (0.50 log units), on the high side; the measured number falls inside the stated range.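

In this assay, compound 3 is the only one of the three compounds shown to return a number rather than a limit, and the exchange of thiophen-2-yl for thiophen-3-yl, with the atom counts unchanged, brings an at least 3.1-fold lower number from compound 2 to compound 3 (0.50 log units; beyond the scatter). Thiophen-3-yl alone does not account for this, since compound 1 carries it too, and methyl in place of dimethylamino on the aromatic carbon brings an at least 4.2-fold lower number from compound 1 to compound 3 (0.62 log units; beyond the scatter); among these compounds, a number appears only where thiophen-3-yl and methyl occur together. The first of these steps therefore gives only a minimum size, as compound 2 is held at a limit and not at a number: the limit of > 15000 nM in this assay, at which 1 of the 3 values shown sits.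

The true size of the second step also stays open, as compound 1 is likewise held at a limit: the limit of > 20000 nM in this assay, at which 1 of the 3 values shown sits. The compounds shown also leave open whether a phenyl ring at this place, or a primary amine or a longer alkyl chain in place of the methyl, would keep, lower or raise the number that compound 3 gives.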